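This account rests on a few compounds, and the source may have more. Where it says the series, first, only, none or still open, it means among the compounds named here.

Of the compounds shown here, three built on a shared core have been measured in a functional assay on LOX IMVI cells (Homo sapiens) for inhibition; a lower number here means a stronger inhibitor of growth, a higher number a weaker inhibitor of growth. Compound 1 `COc1cc(/C=C/C(=O)c2cccc(-n3cc(-c4ccc(Cl)cc4)[nH]c3=O)c2)cc(OC)c1OC` gives 1720 nM in this assay. Compound 2 `COc1cc(/C=C/C(=O)c2cccc(-n3cc(-c4ccccc4)[nH]c3=O)c2)ccc1O` gives 1880 nM in this assay, and compound 3 `O=C(/C=C/c1cccc(O)c1)c1cccc(-n2cc(-c3ccc(Cl)cc3)[nH]c2=O)c1` gives 1570 nM in this assay. Among these three numbers compound 1 holds the second highest, yet its nearest neighbour, compound 2, and its furthest neighbour, compound 3, both lie within the scatter of it, so the three values cannot be told apart.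

Compound 4 `COc1ccc(-c2cn(-c3cccc(C(=O)/C=C/c4cc(OC)c(OC)c(OC)c4)c3)c(=O)[nH]2)cc1` has not yet been measured in this assay. It differs from compound 1 in a single place: methoxy in place of chloro on an aromatic carbon. Among the compounds with values here, no measured pair in this set isolates such a change, and the three measured compounds, which differ from one another in several places at once, all sit at essentially one level. The chemist therefore expects a 1.0-fold lower number from compound 1 to compound 4 (0.01 log units; within the scatter) to be small, in no firm direction, and not beyond the scatter. For compound 4 the estimate is 1700 nM, with a range from 800 nM to 3600 nM.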

Compound 4, concentration for 50% growth inhibition: 720 nM
Beside the measured number, compound 4's estimate is 2.4-fold (0.37 log units) above it; measured number outside the range, below it.
By their numbers in this assay, from the lowest: compound 4; then compounds 3, 1 and 2 (each within the scatter of the next).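

In this assay, replacing chloro with methoxy on this aromatic carbon, para to a large group, gives a 2.4-fold lower number from compound 1 to compound 4 (0.38 log units; beyond the scatter). The earlier compounds shown here, which differ from one another in several places at once and sit at one level, could not show that this position responds to a change of group. The finding rests on this single pair, the step is modest, and nothing available bears on why the number falls.

From the compounds shown here alone, it remains open whether methoxy is special here, or whether an ethoxy group, an amine or a carboxylic acid at this position would give a similar step or a different one. Going by these compounds, it is also open whether the same change would carry over to a compound with the other end of the molecule as it stands in compound 3.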